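This account rests on a few compounds, and the source may have more. Where it says the series, first, only, none or still open, it means among the compounds named here.

Of the compounds shown here, two built on one shared core have so far been tested in a functional assay on MCF7 cells (Homo sapiens) for antiproliferative activity, read by luminescence and CellTiter-Glo, with a stated time of 5 days; on this read-out lower numbers stand for stronger inhibition and higher numbers for weaker inhibition. Compound 1 `CC/C(=C(/c1ccc(/C=C/C(=O)O)cc1)c1[nH]c2ccccc2c1Br)c1ccc(F)cc1Cl` gives 8.53 nM in this assay. Compound 2 `CC/C(=C(/c1ccc(/C=C/C(=O)O)cc1)c1[nH]c2ccccc2c1Cl)c1ccccc1C(F)(F)F` gives 13 nM in this assay. Compound 1 holds the lowest of these two numbers, yet its gap to compound 2 lies within the usual scatter of repeated measurements, so neither can be called the stronger inhibitor.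

Compound 3 `CC/C(=C(/c1ccc(/C=C/C(=O)O)cc1)c1[nH]c2ccccc2c1C#N)c1ccc(F)cc1Cl` differs from compound 1 in a single place: cyano in place of bromo on an aromatic carbon. Going by the values given here, no pair of measured compounds isolates this exchange, so any expectation rests on compound 1 alone. The step from compound 1 to compound 3 is expected to be small, a 1.4-fold higher number from compound 1 to compound 3 (0.15 log units; within the scatter), leaning slightly towards weaker inhibition but not clearly beyond the scatter. Compound 3 is therefore estimated at 12 nM in this assay, within a range from 4 nM to 40 nM.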

Compound 3, half-maximal inhibitory concentration: 4.85 nM
For compound 3 the middle estimate is 2.5-fold (0.39 log units) above the measured one; low and high end bracket the measured number.
By their numbers in this assay, from the lowest: compounds 3, 1 and 2 (each within the scatter of the next, the first and the last beyond it).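

Cyano in place of bromo on this aromatic carbon of the five-membered ring gives a 1.8-fold lower number from compound 1 to compound 3 (0.25 log units; within the scatter) in this assay, so this read-out does not separate the two groups. Going by these compounds alone, this is the first direct exchange at this position, and it shows that a cyano, with two heavy atoms and one hydrogen-bond acceptor, can replace a bromo, with one heavy atom and no acceptor, without a step beyond the scatter. No measurement is available that would explain this result.

Within the data shown here, the exchange has been seen on only one compound pair, so it remains unknown whether it would give a similar step alongside the other substituents of compound 2. As far as these compounds go, it is also open whether a quite different group here, such as an amine or a methoxy, would stay within the scatter of compound 1.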